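A halogenated aryl replaces three methoxy groups

This account rests on a few compounds, and the source may have more. Where it says the series, first, only, none or still open, it means among the compounds named here.

This small series keeps one shared core and varies only the aryl group on a carbon with a double bond to nitrogen. Compound 1 `COc1ccc(/C=N/NC(=O)Nc2ccc(Oc3ccnc(-c4nncn4CCN(C)C)c3)c(F)c2)c(OC)c1OC` carries a 2,3,4-trimethoxyphenyl there, and in a functional assay on U-87MG ATCC cells (Homo sapiens) for cytotoxicity, read by MTT assay, with a stated time of 72 h (a lower number here means a stronger inhibitor, a higher number a weaker inhibitor), compound 1 gives 7650 nM, the highest of the two plain numbers in this assay. Compound 2 `CN(C)CCn1cnnc1-c1cc(Oc2ccc(NC(=O)N/N=C/c3c(O)ccc4ccccc34)cc2F)ccn1` gives 620 nM, a step of a 12-fold lower number from compound 1 to compound 2 (1.09 log units; beyond the scatter). Compound 3 `COc1ccc(/C=N/NC(=O)Nc2ccc(Oc3ccnc(-c4nncn4CCN(C)C)c3)c(F)c2)cc1O` reaches only a limit of the assay, > 100000 nM. The step of an at least 13-fold higher number from compound 1 to compound 3 (1.11 log units; beyond the scatter) therefore runs the opposite way, and the limit of > 100000 nM in this assay, at which 1 of the 3 values shown sits, marks where that value stops.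

Compound 4 `CN(C)CCn1cnnc1-c1cc(Oc2ccc(NC(=O)N/N=C/c3ccc(F)cc3Cl)cc2F)ccn1` has not yet been measured; it differs from compound 1 by 2-chloro-4-fluorophenyl in place of 2,3,4-trimethoxyphenyl on a carbon with a double bond to nitrogen. Both measured changes at this carbon were large, one lowering and one raising the number, so a large step in either direction is possible, yet neither change resembles a halogenated phenyl. For compound 4 a modest improvement is expected, a 2.6-fold lower number from compound 1 to compound 4 (0.41 log units; beyond the scatter), with an estimate of 3000 nM and a range from 600 nM to 20000 nM.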

Compound 4, half-maximal inhibitory concentration: 1210 nM
Beside the measured number, compound 4's estimate is 2.5-fold (0.39 log units) above it; measured number inside the range.
By their numbers in this assay, from the lowest: compounds 2 and 4 (each within the scatter of the next); then compound 1. At a limit, above all of these: compound 3.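

The 2-chloro-4-fluorophenyl has no hydrogen-bond donors or acceptors, yet in this assay the change gives a 6.3-fold lower number from compound 1 to compound 4 (0.80 log units; beyond the scatter), so a lower number at this carbon is reached here with no oxygen on the group. The 2-hydroxynaphthalen-1-yl is also no longer alone among the lower numbers: the step of a 2.0-fold higher number from compound 2 to compound 4 (0.29 log units; within the scatter) stays within the scatter, so these two compounds cannot be told apart. The step of an at least 82-fold lower number from compound 3 to compound 4 (1.91 log units; beyond the scatter) starts from a limit of the assay, not from a plain number: the limit of > 100000 nM in this assay, at which 1 of the 4 values shown sits.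

The compounds shown do not separate the effect of the chlorine from that of the fluorine, which a 2-chlorophenyl and a 4-fluorophenyl at this carbon could do. They also leave open how a 4-aminophenyl or a 4-carboxyphenyl would read in this assay.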